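Nitro for methyl on the pendant phenyl: solubility outlook

The source may report more compounds than this note shows. Statements on the series, on what has been measured and on what is new or still open speak of the compounds shown alone.

In a physicochemical assay for solubility, in phosphate buffer, at pH 7.4 (a higher number here means a more soluble compound, a lower number a less soluble compound), compound 3 `CCOC(=O)c1c(-c2cccc(C)c2)[nH]c2cc(OC)ccc2c1=O` gives 48000 nM, the lower of the two numbers shown, though its gap to compound 2 `CCOC(=O)c1c(-c2cccc(Cl)c2)[nH]c2cc(OC)ccc2c1=O` at 58000 nM lies within the scatter. Compound 1 `CCOC(=O)c1c(-c2ccccc2C)[nH]c2cc(OC)ccc2c1=O` reports only a limit in this assay, > 100000 nM. The two steps from that limit read an at least 1.7-fold lower number from compound 1 to compound 2 (0.23 log units; that floor lies within the scatter) and an at least 2.0-fold lower number from compound 1 to compound 3 (0.31 log units; beyond the scatter), both capped by the limit of > 100000 nM in this assay, at which 1 of the 3 values shown sits; the step between the two real numbers is a 1.2-fold lower number from compound 2 to compound 3 (0.08 log units; within the scatter).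

Compound 4 `CCOC(=O)c1c(-c2cccc([N+](=O)[O-])c2)[nH]c2cc(OC)ccc2c1=O` is not yet measured in this assay. The change is nitro in place of methyl on an aromatic carbon. Of the measured steps only a 1.2-fold lower number from compound 2 to compound 3 (0.08 log units; within the scatter) exchanges the group on that same aromatic carbon, and it stays within the scatter. Within the data shown here, no measured step introduces a nitro, so the chloro-for-methyl exchange is the nearest guide, and it argues for little movement. For compound 4 the expected step is a 1.1-fold lower number from compound 3 to compound 4 (0.03 log units; within the scatter), in no firm direction and not beyond the scatter. The estimate for compound 4 is 45000 nM, expected to fall between 18000 nM and 110000 nM.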

Compound 4, solubility: 13000 nM
For compound 4 the middle estimate is 3.5-fold (0.54 log units) above the measured one; the measured number lies below the stated range.
By their numbers in this assay, from the lowest: compound 4; then compounds 3 and 2 (each within the scatter of the next). At a limit, above all of these: compound 1.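

In this assay, the aromatic carbon meta to a large group proves sensitive to the group it carries: nitro gives a 3.7-fold lower number from compound 3 to compound 4 (0.57 log units; beyond the scatter) and a 4.5-fold lower number from compound 2 to compound 4 (0.65 log units; beyond the scatter), both beyond the scatter, whereas methyl and chloro at this carbon stayed within it. Compound 4 therefore holds the lowest number of the four, and the methyl-chloro pair turns out to be a poor guide to the wider range of groups at this carbon. The comparison with the 2-methylphenyl compound gives an at least 7.6-fold lower number from compound 1 to compound 4 (0.88 log units; beyond the scatter), which is only a floor, since compound 1 reports a limit: the limit of > 100000 nM in this assay, at which 1 of the 4 values shown sits.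

Going by these compounds, whether the drop belongs to nitro alone or would also follow a nitrile, a carboxylic acid or an amine at this carbon remains open. Nothing shown here accounts for the drop.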